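The source may report more compounds than this note shows. Statements on the series, on what has been measured and on what is new or still open speak of the compounds shown alone.

Compound 2 `CCOc1ncc(-c2nc(C(F)(F)F)sc2N2CCN(C(=O)Cn3cnc4cccnc43)[C@H](C)C2)cn1` is one of three close relatives that share a core and differ only in the group on the pyrimidine ring. In an assay on blood for inhibition of C-X-C chemokine receptor type 3 (Homo sapiens), with a stated time of 30 min (a higher number here means a weaker inhibitor, a lower number a stronger inhibitor), compound 2 gives 48 nM. Compound 1 `COc1ncc(-c2nc(C(F)(F)F)sc2N2CCN(C(=O)Cn3cnc4cccnc43)[C@H](C)C2)cn1`, which carries a methoxy group there, gives 158 nM in this assay, and compound 3 `CCCc1ncc(-c2nc(C(F)(F)F)sc2N2CCN(C(=O)Cn3cnc4cccnc43)[C@H](C)C2)cn1`, with a propyl group, gives 45 nM. The two measured steps towards compound 2 and compound 3 run the same way: a 3.3-fold lower number from compound 1 to compound 2 (0.52 log units; beyond the scatter), and a 3.5-fold lower number from compound 1 to compound 3 (0.55 log units; beyond the scatter). Between compound 2 and compound 3 the gap is small: a 1.1-fold lower number from compound 2 to compound 3 (0.03 log units; within the scatter). So compound 2 sits with compound 3 at the stronger end of the three.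

Compound 4 `CCOc1ncc(-c2nc(C(F)(F)F)sc2N2CCN(C(=O)Cn3nc(C)nc3C)[C@H](C)C2)cn1` changes a different part of the molecule. The difference from compound 2 is a group of 7 heavy atoms (4 carbon, 3 nitrogen; one five-membered aromatic ring with 3 hetero atoms) in place of a group of 9 heavy atoms (6 carbon, 3 nitrogen; one five-membered aromatic ring with 2 hetero atoms, one six-membered aromatic ring with 1 hetero atom), on a saturated chain carbon bound to a carbonyl carbon. Among the measured compounds shown here, none of the measured steps touches this position; all three concern the group on the pyrimidine ring, so they give no direct guide to the size or direction of this step. A smaller aromatic group replaces a fused two-ring system, and without any comparable measured step the expectation is uncertain and leans toward some loss. For compound 4 the expected step is a 3.1-fold higher number from compound 2 to compound 4 (0.49 log units; beyond the scatter), and the estimate is 150 nM, within a range from 40 nM to 600 nM.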

Compound 4, half-maximal inhibitory concentration: 364 nM
Compound 4: middle estimate off by 2.4-fold (0.39 log units), on the low side, and the stated range covers the measured number.
By their numbers in this assay, from the lowest: compounds 3 and 2 (each within the scatter of the next); then compound 1; then compound 4.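

In this assay the group on the saturated chain carbon bound to a carbonyl carbon clearly matters: replacing the group with a five-membered and a six-membered aromatic ring by 3,5-dimethyl-1H-1,2,4-triazol-1-yl gives a 7.6-fold higher number from compound 2 to compound 4 (0.88 log units; beyond the scatter) for this single change. Among the compounds shown here, this step runs towards a weaker inhibitor, unlike the earlier steps on the pyrimidine ring, and it is larger than a 3.3-fold lower number from compound 1 to compound 2 (0.52 log units; beyond the scatter) in the opposite direction, so this position can shift the number by more than those earlier changes did. The two groups have the same counts of hydrogen-bond donors and acceptors and the same net charge, so these counts do not separate them, and nothing measured here accounts for the loss.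

The compounds shown cannot separate the effect of the two methyl groups from that of replacing the two-ring group with a single ring, a question that the plain 1H-1,2,4-triazol-1-yl group or a benzimidazol-1-yl group could help to answer. Going by these compounds, it also remains open whether swapping ethoxy for methoxy or propyl on the pyrimidine ring would have the same effect when this triazole group is present.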